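The source may report more compounds than this note shows. Statements on the series, on what has been measured and on what is new or still open speak of the compounds shown alone.

Values in a physicochemical assay for solubility, measured as kinetic solubility; on this read-out lower numbers stand for lower solubility and higher numbers for higher solubility
- compound 1 (`Cc1cnc(NC(=O)c2cc(Oc3cnc(C(=O)N(C)C)cn3)c3cc(C)oc3c2)cn1`) gives 176000 nM
- compound 2 (`Cc1cnc(NC(=O)c2cc(Oc3cnc(C(=O)N(C)C)cn3)c3cn(C)nc3c2)cn1`) gives 192000 nM
- compound 3 (`Cc1cnc(NC(=O)c2cc(Oc3ccc(C(=O)N(C)C)cc3)c3cn(C)nc3c2)cn1`) gives 351000 nM

Compound 3 (351000 nM) lies within the usual scatter of both other compounds, so these three values give no ranking. The next compound to be tested, compound 4 (`Cc1cnc(NC(=O)c2cc(Oc3ccc(S(=O)(=O)N(C)C)cc3)c3cn(C)nc3c2)cn1`), has dimethylsulfamoyl in place of dimethylcarbamoyl on an aromatic carbon, para to a large group (dimethylsulfamoyl in place of dimethylcarbamoyl on an aromatic carbon). For the measured compounds named here, no two measured compounds differ in one place only, so no measured step guides this change. A modest fall in this assay is expected, estimated as (a 2.3-fold lower number from compound 3 to compound 4 (0.37 log units; beyond the scatter)). That direction is a judgement and not a measured trend, so the range is kept wide. For compound 4 the estimated value is 150000 nM (expected range 40000 nM to 350000 nM).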

Compound 4, solubility: 134000 nM
For compound 4 the middle estimate is 1.1-fold (0.05 log units) above the measured one; measured number inside the range.
By their numbers in this assay, from the lowest: compounds 4, 1, 2 and 3 (each within the scatter of the next, the first and the last beyond it).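

In this assay, for the compounds shown here, this is the first comparison that changes one group alone: replacing dimethylcarbamoyl with dimethylsulfamoyl on the aromatic carbon, para to a large group, gives a 2.6-fold lower number from compound 3 to compound 4 (0.42 log units; beyond the scatter). The earlier compounds shown here could not isolate any single change, whereas this pair shows that the number at this position responds to the group placed there. Nothing available explains the fall.

This single pair does not show whether the same swap would give a similar step on another core. Going by these compounds, how a nitrile, a carboxylic acid or an amine at this position would compare also remains open.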